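Cyano for Bromo: Expecting Compound 4 from One Pair

The source may hold more compounds than are shown below. What is called first, only, known or untested is meant among the compounds shown, and "the series" means these compounds.

Compound 1 `O=C1/C(=C/c2ccncc2)CN(S(=O)(=O)c2ccc(Br)cc2)C/C1=C\c1ccccc1F` and compound 2 `N#Cc1ccc(S(=O)(=O)N2C/C(=C\c3ccncc3)C(=O)/C(=C/c3ccccc3F)C2)cc1` share one core; in a functional assay on HepG2 cells (Homo sapiens) for cytotoxicity, read by MTT assay, with a stated time of 24 h (on this read-out higher numbers stand for weaker inhibition and lower numbers for stronger inhibition), compound 1 gives 9300 nM and compound 2 gives 4500 nM. The change between them is cyano in place of bromo on an aromatic carbon, and it made a 2.1-fold lower number from compound 1 to compound 2 (0.32 log units; beyond the scatter). Compound 3 `O=C1/C(=C/c2ccncc2)CN(S(=O)(=O)c2ccc(Br)cc2)C/C1=C\c1ccccc1C(F)(F)F` differs from compound 1 by trifluoromethyl in place of fluoro on an aromatic carbon; in this assay compound 3 gives 14500 nM, which is a 1.6-fold higher number from compound 1 to compound 3 (0.19 log units; within the scatter). Compound 4 `N#Cc1ccc(S(=O)(=O)N2C/C(=C\c3ccncc3)C(=O)/C(=C/c3ccccc3C(F)(F)F)C2)cc1` stands to compound 3 as compound 2 stands to compound 1: the change is cyano in place of bromo on an aromatic carbon, the same change at the same place. Compound 4 has not yet been measured in this assay. Among the measured compounds shown here, because the only earlier instance of this change gave a 2.1-fold lower number from compound 1 to compound 2 (0.32 log units; beyond the scatter), the step from compound 3 to compound 4 is expected to be about a 2.1-fold lower number from compound 3 to compound 4 (0.32 log units; beyond the scatter), an expectation resting on a single pair. Compound 4 is therefore estimated at 7000 nM, with a likely range from 3500 nM to 14000 nM.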

Compound 4, half-maximal inhibitory concentration: 5920 nM
Estimate against measurement, compound 4: 1.2-fold (0.07 log units) above; the range from low to high includes it.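

In this assay, cyano in place of bromo gave a 2.4-fold lower number from compound 3 to compound 4 (0.39 log units; beyond the scatter), and the step carried from the core of compound 1 to that of compound 3 without a difference beyond the scatter: the same change on two cores in this assay, a 2.1-fold lower number (0.32 log units; beyond the scatter) from compound 1 to compound 2 and a 2.4-fold lower number (0.39 log units; beyond the scatter) from compound 3 to compound 4, 1.2-fold (0.07 log units) apart, within the scatter of two such steps. Trifluoromethyl in place of fluoro gave a 1.3-fold higher number from compound 2 to compound 4 (0.12 log units; within the scatter), and this change also held with either bromo or cyano present: the same change on two cores in this assay, a 1.6-fold higher number (0.19 log units; within the scatter) from compound 1 to compound 3 and a 1.3-fold higher number (0.12 log units; within the scatter) from compound 2 to compound 4, 1.2-fold (0.07 log units) apart, within the scatter of two such steps. This shows that the two changes behaved independently across these four compounds, but it rests on two cores and does not show that either step would carry to other cores in the series.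

The compounds shown leave open what an amine or a carboxylic acid would give on that aromatic carbon in place of bromo or cyano. They also leave open whether a methoxy group in place of fluoro or trifluoromethyl would follow the same pattern.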